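The source may report more compounds than this note shows. Statements on the series, on what has been measured and on what is new or still open speak of the compounds shown alone.

Measured in a functional assay (mast cells) for inhibition, with Rattus norvegicus as the target; a lower number here means that less compound is needed, a higher number that more compound is needed for the effect:
- compound 1 `CCOC(=O)c1cnc2n(c1=O)C(C)CC/C2=N\Nc1ccccc1C(=O)O`: 100000 nM
- compound 2 `CC1C/C(=N\Nc2ccccc2)c2ncc(C(=O)O)c(=O)n2C1`: 13000 nM
- compound 3 `CC1CC/C(=N\Nc2ccc(F)cc2)c2ncc(C(=O)O)c(=O)n21`: 1200 nM

Compound 3 stands lowest of these three, and its gaps to compound 2 and compound 1 both lie beyond the scatter. Compound 4 `CC1CC/C(=N\Nc2ccc(O)cc2)c2ncc(C(=O)O)c(=O)n21` has hydroxy in place of fluoro on an aromatic carbon, para to a large group (hydroxy in place of fluoro on an aromatic carbon). Among the measured compounds shown here, no measured pair in this assay shows this exchange, so the expectation is loose and starts from compound 3 at 1200 nM. A small step toward a higher number is expected, possibly within the scatter, and the estimate is a 1.7-fold higher number from compound 3 to compound 4 (0.22 log units; within the scatter). For compound 4 the expected value is 2000 nM, with an estimated range of 400 nM to 10000 nM.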

Compound 4, half-maximal effective concentration: 1300 nM
For compound 4 the middle estimate is 1.5-fold (0.19 log units) above the measured one, and the stated range covers the measured number.
By their numbers in this assay, from the lowest: compounds 3 and 4 (each within the scatter of the next); then compound 2; then compound 1.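

In this assay the exchange of fluoro for hydroxy on an aromatic carbon, para to a large group, gives a 1.1-fold higher number from compound 3 to compound 4 (0.03 log units; within the scatter) and so stays within the scatter. Among the compounds shown here, this is the first readable exchange at this position, and the number does not separate the two groups, even though hydroxy carries a hydrogen-bond donor and acceptor and fluoro carries neither. No measured evidence bears on this result.

Going by these compounds, whether a methoxy group or an amine at this position would also stay within the scatter of compound 3 remains open. So does whether the same exchange would read alike on the core of compound 2.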